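The compounds below may be only part of what the source reports. "The series", "measured", "known", "first", "only" and "open" are said of these compounds alone.

Three compounds share one core. Compound 1, `CCOC(=O)C1=C(N/N=C(/C(=O)Br)c2ccc(Cl)cc2)Nc2[nH]nc(C)c2C1c1ccc(N(C)C)cc1`, gives 49300 nM in a functional assay on HeLa cells (Homo sapiens) for inhibition, read by MTT assay, with a stated time of 48 h; a lower number here means a stronger inhibitor, a higher number a weaker inhibitor; compound 2, `CCOC(=O)C1=C(N/N=C(/C(=O)Br)c2ccc(Br)cc2)Nc2[nH]nc(C)c2C1c1ccc(N(C)C)cc1`, gives 68500 nM; and compound 3, `CCOC(=O)C(=NNC1=C(C(=O)OCC)C(c2ccc(N(C)C)cc2)c2c(C)n[nH]c2N1)C(=O)OCC`, gives 83800 nM. Compound 3 has the highest number of the three, yet its gap to compound 2 and to compound 1 stays within the scatter. Compound 4, `CCOC(=O)C1=C(N/N=C(/C#N)C(=O)OCC)Nc2[nH]nc(C)c2C1c1ccc(N(C)C)cc1`, differs from compound 3 in one place: a group of 9 heavy atoms (5 carbon, 2 nitrogen, 2 oxygen; no ring) in place of a group of 12 heavy atoms (7 carbon, 1 nitrogen, 4 oxygen; no ring), on an amine nitrogen. Among the compounds with values here, two measured steps touch the same group on the amine nitrogen, a 1.7-fold higher number from compound 1 to compound 3 (0.23 log units; within the scatter) and a 1.2-fold higher number from compound 2 to compound 3 (0.09 log units; within the scatter), and neither leaves the scatter. Compound 4 is therefore expected to give a number close to that of compound 3, with a step of about a 1.2-fold lower number from compound 3 to compound 4 (0.08 log units; within the scatter). The estimate for compound 4 is 70000 nM, in a range from 25000 nM to 200000 nM.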

Compound 4, half-maximal inhibitory concentration: 39200 nM
Estimate against measurement, compound 4: 1.8-fold (0.25 log units) above; the range from low to high includes it.
By their numbers in this assay, from the lowest: compounds 4, 1, 2 and 3 (each within the scatter of the next, the first and the last beyond it).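

In this assay, the group on the amine nitrogen gives its first step beyond the scatter, a modest one: a 2.1-fold lower number from compound 3 to compound 4 (0.33 log units; beyond the scatter) when the nitrile-bearing group replaces the ring-free group of compound 3. Measured against the groups carrying the six-membered aromatic ring, the same nitrile-bearing group stays within the scatter, with a 1.7-fold lower number from compound 2 to compound 4 (0.24 log units; within the scatter) and a 1.3-fold lower number from compound 1 to compound 4 (0.10 log units; within the scatter) in those comparisons. Nothing available explains the step. As far as these compounds go, whether a carboxylic acid, an amine or a longer chain on this amine nitrogen would move the number further remains open.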